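The source may hold more compounds than are shown below. What is called first, only, known or untested is meant among the compounds shown, and "the series" means these compounds.

Three compounds share one core and differ only in the chain attached to the triple-bonded carbon. Compound 1 `CN[C@@H](C#Cc1c(F)ccc2c1/C(=C/c1[nH]ccc1OC)C(=O)N2)CO` and compound 2 `CN[C@H](C#Cc1c(F)ccc2c1/C(=C/c1[nH]ccc1OC)C(=O)N2)CO` carry a 2-hydroxy-1-(methylamino)ethyl chain and differ only in configuration, the fact recorded as the fact that compounds 1 and 2 differ only in the configuration as drawn. Compound 3 `COc1cc[nH]c1/C=C1\C(=O)Nc2ccc(F)c(C#C[C@H](CO)NCCO)c21` carries instead a 2-hydroxy-1-((2-hydroxyethyl)amino)ethyl chain. In a functional assay on MDA-MB-435 cells (Homo sapiens) for inhibition (on this read-out higher numbers stand for weaker inhibition and lower numbers for stronger inhibition), compound 1 gives 300 nM, compound 2 gives 349 nM, and compound 3 gives 1270 nM. On these numbers compound 3 stands highest, that is weakest, of the three: the step of a 4.2-fold higher number from compound 1 to compound 3 (0.63 log units; beyond the scatter) and the step of a 3.6-fold higher number from compound 2 to compound 3 (0.56 log units; beyond the scatter) are both beyond the scatter, while the step of a 1.2-fold higher number from compound 1 to compound 2 (0.07 log units; within the scatter) is not.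

Compound 4 `CN[C@H](C#Cc1c(F)ccc2c1/C(=C/c1[nH]ccc1OC)C(=O)N2)[C@@H](C)O` has not yet been measured in this assay. It differs from compound 3 by 2-hydroxy-1-(methylamino)propyl in place of 2-hydroxy-1-((2-hydroxyethyl)amino)ethyl on a triple-bonded carbon. This change undoes the exchange that made compound 3 weaker than compound 1 and compound 2, and adds one methyl on the chain carbon bearing the hydroxyl. The two measured steps toward compound 3 were both modest rises, so a drop of similar size is expected in this assay, with the extra methyl an unknown of its own. For compound 4 the expected value is 400 nM, between 150 nM and 1100 nM, an expected step of a 3.2-fold lower number from compound 3 to compound 4 (0.50 log units; beyond the scatter).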

Compound 4, half-maximal inhibitory concentration: 358 nM
Estimate against measurement, compound 4: 1.1-fold (0.05 log units) above; low and high end bracket the measured number.
By their numbers in this assay, from the lowest: compounds 1, 2 and 4 (each within the scatter of the next); then compound 3.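

Going back from the 2-hydroxy-1-((2-hydroxyethyl)amino)ethyl chain to a methylamino chain, in this assay, gives a 3.5-fold lower number from compound 3 to compound 4 (0.55 log units; beyond the scatter), so the higher number of compound 3 is not a fixed feature of the shared core and can be reversed by a change on this triple-bonded carbon. The new information is the extra methyl on the chain carbon bearing the hydroxyl, which gives a 1.0-fold higher number from compound 2 to compound 4 (0.01 log units; within the scatter) and a 1.2-fold higher number from compound 1 to compound 4 (0.08 log units; within the scatter): both steps lie within the scatter, so this chain accepts that methyl and a second defined stereocentre without a readable change in this cell assay. Nothing recorded here accounts for the size of any of these steps.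

Only one drawn configuration appears at the carbon bearing the hydroxyl in the 2-hydroxy-1-(methylamino)propyl chain, so the opposite configuration there, or a longer chain such as an ethyl or propyl group on that carbon, remains an open question. Going by these compounds, it is also open whether the higher number of compound 3 goes with the hydroxyl on the amine substituent or with the substituent's size, and a simple ethyl group on the amine nitrogen would help to separate the two.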